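This account rests on a few compounds, and the source may have more. Where it says the series, first, only, none or still open, it means among the compounds named here.

Compound 1 `Cc1ccc(N2C(=O)CSC2c2sc(Cc3ccc(Cl)cc3)nc2C)cc1`: 61.4%
Compound 2 `Cc1nc(-c2ccc(Cl)cc2)sc1C1SCC(=O)N1c1ccc(F)cc1`: 63.9%

Of the compounds shown here, two have been measured in a functional assay on the whole organism (strain Wistar albino) for inhibition, with Rattus norvegicus as the target, read by paw edema, with stated times of 1 h and 2 h, at a dose of 40 mg/kg by the oral route; a lower number here means less inhibition, a higher number more inhibition at the dose given (going by the name of the read-out). Compound 1 gives 61.4%, and compound 2 gives 63.9%. Compound 2 shows the higher of the two numbers, but its gap to compound 1 lies within the scatter, so the two read alike. Compound 3 `Cc1ccc(N2C(=O)CSC2c2sc(-c3ccc(Cl)cc3)nc2C)cc1` is not yet measured in this assay. It differs from compound 2 as follows: methyl in place of fluoro on an aromatic carbon. Compound 1 carries the same 4-methylphenyl group that enters here, on a core that otherwise differs from compound 2 in one place, and its value sits close to that of compound 2. Within the data shown here, no measured pair shows this single change, so there is no step to draw on; the expectation is for a step from compound 2 to compound 3 of a number 1.9 percentage points lower from compound 2 to compound 3 (within the scatter), no larger than the scatter. Compound 3 is thus expected to give about 62% in this assay, within a range from 52% to 72%.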

Compound 3, a percentage reported as inhibition, in the whole organism at one dose (the size of the read-out at that dose, not a potency): 37.6%
The estimate for compound 3 lay 24.4 percentage points above the measured number; the whole stated range lies above it.
By their numbers in this assay, from the lowest: compound 3; then compounds 1 and 2 (each within the scatter of the next).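

In this assay, methyl in place of fluoro on an aromatic carbon goes with a number 26.3 percentage points lower from compound 2 to compound 3 (beyond the scatter) and shows that this place, para to a large group, is sensitive to the exchange of a single heavy atom. The 4-methylphenyl group alone does not fix the read-out, as 4-chlorophenyl in place of 4-chlorobenzyl, with that group kept, goes with a number 23.8 percentage points lower from compound 1 to compound 3 (beyond the scatter) on an otherwise unchanged structure. The two changes thus each matter on their own terms.

On these data alone, whether a methoxy group or an amine at this place would read like the fluoro compound or like the methyl compound remains open. So does the size of the same methyl for fluoro change with the 4-chlorobenzyl group in place, and nothing at hand accounts for either step.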